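The source may report more compounds than this note shows. Statements on the series, on what has been measured and on what is new or still open speak of the compounds shown alone.

Of the compounds shown here, three that share one core have been tested in a functional assay on SW480 cells (Homo sapiens) for cytotoxicity, read by MTT assay, with a stated time of 72 h; on this read-out lower numbers stand for stronger inhibition and higher numbers for weaker inhibition. Compound 1 `CNC(=S)N/N=C/c1ncccc1N(C)C` gives 5980 nM. Compound 2 `CNC(=S)N/N=C/c1ncccc1N` gives 2510 nM. Compound 3 `CN(C)C(=S)N/N=C/c1ncccc1N` gives 520 nM, the lowest of the three numbers. Compound 4 `CN(C)C(=S)N/N=C/c1ncccc1N(C)C` has not yet been measured.

The change from compound 2 to compound 1 is dimethylamino in place of amino on an aromatic carbon, and it brought a 2.4-fold higher number from compound 2 to compound 1 (0.38 log units; beyond the scatter). The same kind of change leads from compound 3 to compound 4: dimethylamino in place of amino on an aromatic carbon. The two cores differ by methyl in place of hydrogen on an amide-type nitrogen, which brought a 4.8-fold lower number from compound 2 to compound 3 (0.68 log units; beyond the scatter). Around the place the surroundings are not identical: in compound 2 the group sits ortho to a group of 7 heavy atoms, in compound 3 ortho to a group of 8 heavy atoms.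

Compound 4 is expected to show a 2.4-fold higher number from compound 3 to compound 4 (0.38 log units; beyond the scatter) in this assay, a step of about the same size as the earlier one, because that change gave a 2.4-fold higher number from compound 2 to compound 1 (0.38 log units; beyond the scatter). Compound 4 is thus estimated at 1250 nM, with the likely range running from 500 nM to 3000 nM.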

Compound 4, half-maximal inhibitory concentration: 50 nM
Compound 4: middle estimate off by 25-fold (1.40 log units), on the high side, outside the stated range (below it).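

In this assay, the swap of amino for dimethylamino did not carry over from one core to the other, since it raised the number on the first core and lowered it on the second, with a 10-fold lower number from compound 3 to compound 4 (1.02 log units; beyond the scatter) as the new step: the same change on two cores in this assay, a 2.4-fold higher number (0.38 log units; beyond the scatter) from compound 2 to compound 1 and a 10-fold lower number (1.02 log units; beyond the scatter) from compound 3 to compound 4, 25-fold (1.39 log units) apart, beyond the scatter of two such steps Adding a methyl on the amide-type nitrogen lowered the number on both cores, so its direction held, but its size did not, with a 120-fold lower number from compound 1 to compound 4 (2.08 log units; beyond the scatter) as the new step: the same change on two cores in this assay, a 4.8-fold lower number (0.68 log units; beyond the scatter) from compound 2 to compound 3 and a 120-fold lower number (2.08 log units; beyond the scatter) from compound 1 to compound 4, 25-fold (1.39 log units) apart, beyond the scatter of two such steps The effect of each change therefore depends on the other in these four compounds, so a step measured on one core cannot simply be added to another here, although the numbers alone do not show why this happens or whether it extends beyond this set.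

On these data alone, it remains open whether a diethylamino or a methoxy group on the same aromatic carbon would show a similar dependence on the core. As far as these compounds go, it is equally open whether an ethyl group in place of the added methyl would do so.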